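The source may hold more compounds than are shown below. What is called first, only, known or untested is meant among the compounds shown, and "the series" means these compounds.

Measured so far in an assay on HEK293 cells for displacement of a labelled ligand from D(3) dopamine receptor (Rattus norvegicus); a higher number here means a weaker inhibitor, a lower number a stronger inhibitor:
Compound 1 `CCCN(CCN1CCN(c2ccc(-c3cccc(OC)c3)cc2)CC1)C1CCc2nc(N)sc2C1` gives 2.11 nM.
Compound 2 `CCCN(CCN1CCN(c2ccc(-c3ccc(O)cc3)cc2)CC1)C1CCc2nc(N)sc2C1` gives 1.17 nM.
Compound 3 `CCCN(CCN1CCN(c2ccc(-c3cccc(O)c3)cc2)CC1)C1CCc2nc(N)sc2C1` gives 1.2 nM.

Compound 3 has the second highest of the three numbers, but the set is flat: a 1.8-fold lower number from compound 1 to compound 3 (0.25 log units; within the scatter), a 1.0-fold higher number from compound 2 to compound 3 (0.01 log units; within the scatter), and on the other side a 1.8-fold lower number from compound 1 to compound 2 (0.26 log units; within the scatter). All three steps concern only the terminal aromatic ring and its oxygen substituent, and none of them separates the compounds beyond the scatter.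

Compound 4 `CCCN(CCN1CCN(c2ccc(-c3cccc(O)c3)cc2)CC1)C1CCc2nc(N)ncc2C1` differs from compound 3 at the amine nitrogen whose other neighbours are two saturated chain carbons: a group of 11 heavy atoms (8 carbon, 3 nitrogen; one six-membered non-aromatic ring of carbon only, one six-membered aromatic ring with 2 hetero atoms) in place of a group of 10 heavy atoms (7 carbon, 2 nitrogen, 1 sulfur; one five-membered aromatic ring with 2 hetero atoms, one six-membered non-aromatic ring of carbon only), on an amine nitrogen. The aromatic ring carrying the amino group of the shared core is thus exchanged, a five-membered aromatic ring with two hetero atoms giving way to a six-membered aromatic ring with two hetero atoms. Going by the values given here, none of the measured steps touches this part of the structure, so no step bears on it directly, and the expectation rests on the change alone. Since the alteration sits in the shared core rather than at the periphery where the flat steps were seen, a modest weakening is expected, a 2.9-fold higher number from compound 3 to compound 4 (0.46 log units; beyond the scatter), with broad uncertainty. Compound 4 is therefore estimated at 3.5 nM, within a range of 0.8 nM to 15 nM.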

Compound 4, inhibition constant: 67 nM
Beside the measured number, compound 4's estimate is 19-fold (1.28 log units) below it; measured number outside the range, above it.
By their numbers in this assay, from the lowest: compounds 2, 3 and 1 (each within the scatter of the next); then compound 4.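

In this assay, the group on the amine nitrogen whose other neighbours are two saturated chain carbons proves far less forgiving than the terminal aromatic ring: a 56-fold higher number from compound 3 to compound 4 (1.75 log units; beyond the scatter), while every step among compound 1, compound 2 and compound 3 stayed within the scatter. The leaving and entering groups have equal hydrogen-bond donor and acceptor counts, so these counts do not separate compound 3 from compound 4. No measurement at hand bears on the cause of this step.

With a single pair, the loss of sulfur, the change in ring size and the added ring nitrogen cannot be told apart. Also open, on these data alone, are whether the 3-methoxyphenyl and 4-hydroxyphenyl groups stay interchangeable on the core of compound 4, and how a methylamino group in place of the amino group would fare on either core.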